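The source may hold more compounds than are shown below. What is called first, only, known or untested is meant among the compounds shown, and "the series" means these compounds.

Compound 1 `Fc1cccc(F)c1CSc1nnc(-c2ccncc2)n1-c1ccccc1` shows only a limit in a functional assay on MCF7 cells (Homo sapiens) for inhibition, read by MTT assay, with a stated time of 48 h; on this read-out higher numbers stand for weaker inhibition and lower numbers for stronger inhibition: compound 1 gives > 50000 nM. Compound 2 `O=[N+]([O-])c1ccccc1CSc1nnc(-c2ccncc2)n1-c1ccccc1` likewise stops at a limit in this assay, where compound 2 gives > 50000 nM. The step that the two limits leave unreadable from compound 1 to compound 2 stays unreadable because the limit of > 50000 nM in this assay, at which 2 of the 3 values shown sit, hides its size. Among the compounds with values here, compound 3 `COc1ccc(/C=N/NC(=O)CSc2nnc(-c3ccncc3)n2-c2ccccc2)cc1` is the one compound with a measured number in this assay, where compound 3 gives 23700 nM. Within the data shown here, compound 4 `O=C(CSc1nnc(-c2ccncc2)n1-c1ccccc1)N/N=C/c1cc(Br)cc(Br)c1O` differs from compound 3 in a single place: 3,5-dibromo-2-hydroxyphenyl in place of 4-methoxyphenyl on a carbon with a double bond to nitrogen No measured step bears on this change, so no direction can be drawn from the measured steps. For compound 4 the expected step is a 1.6-fold lower number from compound 3 to compound 4 (0.20 log units; within the scatter), within the usual scatter. Compound 4 is therefore estimated at 15000 nM, with a range from 5000 nM to 50000 nM.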

Compound 4, half-maximal inhibitory concentration: 8440 nM
Estimate against measurement, compound 4: 1.8-fold (0.25 log units) above, within the range that was stated.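

In this assay, within the data shown here, the change on the carbon with a double bond to nitrogen gives a 2.8-fold lower number from compound 3 to compound 4 (0.45 log units; beyond the scatter), the first readable step and one beyond the usual scatter. The group at this place therefore affects the read-out, although the two bromines and the hydroxy group arrive together, so their shares cannot be separated. No measurement here accounts for the step.

Going by these compounds, it remains open whether the hydroxy group or the bromines alone would give the same step. On these data alone, it is also open how an amine or a carboxylic acid on this ring would read.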